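This account rests on a few compounds, and the source may have more. Where it says the series, first, only, none or still open, it means among the compounds named here.

Measured compounds and their values:

- compound 1, `COc1ccccc1/C=N/NC(=O)CSc1nnnn1C`, gives 3160000 nM in an ADME assay on NIH3T3 cells (Mus musculus) for cytotoxicity, read by XTT assay, with a stated time of 24 h; on this read-out lower numbers stand for stronger inhibition and higher numbers for weaker inhibition
- compound 2, `COc1cccc(/C=N/NC(=O)CSc2nnnn2C)c1`, gives 600000 nM in this assay
- compound 3, `Cc1ccccc1/C=N/NC(=O)CSc1nnnn1C`, gives 6320000 nM in this assay

Compounds 1 and 2 are built from the same atoms joined differently; the difference between the two cores is not broken down here. Compound 2 has the lowest number of the three, and its steps to compound 1, the nearest, and to compound 3, the furthest, are both beyond the scatter, so it is the strongest inhibitor measured so far.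

Among the compounds with values here, the one change that is measured directly is methyl in place of methoxy on an aromatic carbon, which gave a 2.0-fold higher number from compound 1 to compound 3 (0.30 log units; within the scatter), a step within the scatter. The unmeasured compound 4, `Cc1cccc(/C=N/NC(=O)CSc2nnnn2C)c1`, carries the same kind of change relative to compound 2: methyl in place of methoxy on an aromatic carbon. The place is not identical, since in compound 3 the methyl sits ortho to a large group and in compound 4 it sits meta to a large group, so the two changes are of the same kind rather than the same.

Because a 2.0-fold higher number from compound 1 to compound 3 (0.30 log units; within the scatter) was within the scatter, compound 4 is expected to stay close to compound 2, with a small rise in the number possible; the estimated step is a 1.5-fold higher number from compound 2 to compound 4 (0.18 log units; within the scatter). The expected value for compound 4 in this assay is 900000 nM, with a likely range from 300000 nM to 3000000 nM.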

Compound 4, half-maximal inhibitory concentration: 6250000 nM
Estimate against measurement, compound 4: 6.9-fold (0.84 log units) below; the whole stated range lies below it.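

In this assay, methyl in place of methoxy on an aromatic carbon gave a 10-fold higher number from compound 2 to compound 4 (1.02 log units; beyond the scatter), a large step on the core of compound 2, whereas the same kind of change on the core of compound 1 stayed within the scatter. Within the data shown here, the size of this change therefore did not carry over from one core to the other, so a result on one core was a poor guide to the other in this pair of cases: the same change on two cores in this assay, a 2.0-fold higher number (0.30 log units; within the scatter) from compound 1 to compound 3 and a 10-fold higher number (1.02 log units; beyond the scatter) from compound 2 to compound 4, 5.2-fold (0.72 log units) apart, beyond the scatter of two such steps This shows only that the two steps differ; it does not show why, and with just two pairs, in which the group also sits at different places on the ring, it offers no rule for any other core.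

The compounds shown leave open how other groups would behave at these places on the ring, such as a hydroxyl, an ethoxy or an amine. They also leave open whether a chlorine or a carboxylic acid in place of the methoxy would show the same gap between the two cores, which would indicate whether the gap is tied to this one change or extends to others.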